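This account rests on a few compounds, and the source may have more. Where it says the series, first, only, none or still open, it means among the compounds named here.

Compound 2 `CC(C)C[C@H](N)c1cc(C(F)(F)F)ccc1N1CCN(C(=O)CSc2ccc(Cl)cc2Cl)CC1` was measured in an assay on HEK293 cells for displacement of a labelled ligand from Melanocortin receptor 4 (Homo sapiens) (a lower number here means a stronger inhibitor, a higher number a weaker inhibitor), where compound 2 gives 1500 nM. Among the three compounds measured so far it stands second highest. Compound 1 `CC(C)C[C@H](N)c1cc(C(F)(F)F)ccc1N1CCN(C(=O)COc2ccc(O)cc2)CC1` gives 4600 nM, and the change between them reads a 3.1-fold lower number from compound 1 to compound 2 (0.49 log units; beyond the scatter). Compound 3 `COc1cc(CC(C)C(=O)N2CCN(c3ccc(C(F)(F)F)cc3[C@@H](N)CC(C)C)CC2)ccc1Cl` gives 230 nM, with the step reading a 6.5-fold lower number from compound 2 to compound 3 (0.81 log units; beyond the scatter), and the longer step reading a 20-fold lower number from compound 1 to compound 3 (1.30 log units; beyond the scatter).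

Compound 4 `CC(C)C[C@H](N)c1cc(C(F)(F)F)ccc1N1CCN(C(=O)COc2ccc(Cl)cc2)CC1` has not yet been measured. It differs from compound 2 in one place: 4-chlorophenoxy in place of (2,4-dichlorophenyl)sulfanyl on a saturated chain carbon bound to a carbonyl carbon. Going by the values given here, the measured step that bears most directly on this is the one between the 4-hydroxyphenoxy group and the (2,4-dichlorophenyl)sulfanyl group, read as a 3.1-fold lower number from compound 1 to compound 2 (0.49 log units; beyond the scatter). The 4-chlorophenoxy group of compound 4 shares the oxygen link with the group of compound 1 and a chlorine with the group of compound 2, so a number between those two measured values is expected. The estimate for compound 4 in this assay is 2500 nM, within a range from 1000 nM to 6000 nM, which corresponds to an expected step of a 1.7-fold higher number from compound 2 to compound 4 (0.22 log units; within the scatter).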

Compound 4, inhibition constant: 2900 nM
The estimate for compound 4 lay 1.2-fold (0.06 log units) below the measured number; the measured number falls inside the stated range.
By their numbers in this assay, from the lowest: compound 3; then compounds 2, 4 and 1 (each within the scatter of the next, the first and the last beyond it).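

Putting 4-chlorophenoxy in place of (2,4-dichlorophenyl)sulfanyl on the saturated chain carbon bound to a carbonyl carbon gives a 1.9-fold higher number from compound 2 to compound 4 (0.29 log units; within the scatter), and chloro in place of hydroxy on an aromatic carbon gives a 1.6-fold lower number from compound 1 to compound 4 (0.20 log units; within the scatter), so neither change clearly shifts the result in this assay. Going by these compounds alone, by contrast, (4-chlorophenoxy)methyl in place of 1-(4-chloro-3-methoxybenzyl)ethyl on a carbonyl carbon gives a 13-fold higher number from compound 3 to compound 4 (1.10 log units; beyond the scatter), the only large step among the new ones. Nothing measured here explains these results.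

On these data alone, the swap of (2,4-dichlorophenyl)sulfanyl for 4-chlorophenoxy changes the sulfur link and removes a chlorine together, so the share of each remains unknown. Also open, as far as these compounds go, is how an amine or a carboxylic acid in place of the chloro would read in this assay, and what a longer chain on the carbonyl carbon would do.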